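This account rests on a few compounds, and the source may have more. Where it says the series, first, only, none or still open, it means among the compounds named here.

Three compounds share one core in which a sulfonyl sulfur carries an aromatic group, and all have been tested in a functional assay on MCF7 cells (Homo sapiens) for antiproliferative activity, read by MTT assay, with a stated time of 48 h; a lower number here means a stronger inhibitor, a higher number a weaker inhibitor. Compound 1 `CC(C)(C)c1ccc(S(=O)(=O)n2cc(/C=C/C(=O)c3ccncc3)c3ccccc32)cc1` gives 24000 nM; "dose-dependent effect" (no number reported) (2 entries), though its record in this assay is uneven: the several entries of compound 1 in this assay, 24000 nM; "dose-dependent effect" (no number reported) (2 entries). Compound 2 `O=C(/C=C/c1cn(S(=O)(=O)c2ccc(Cl)cc2)c2ccccc12)c1ccncc1` gives 37500 nM in this assay, and compound 3 `O=C(/C=C/c1cn(S(=O)(=O)c2ccccc2[N+](=O)[O-])c2ccccc12)c1ccncc1` gives 36900 nM. Of the two plain numbers, compound 3 and compound 2 lie within the scatter of each other, so no order can be read between them. Within the data shown here, the only change measured one step at a time is a 1.0-fold lower number from compound 2 to compound 3 (0.01 log units; within the scatter), which exchanged one aromatic group on the sulfonyl sulfur for another without moving the number beyond the scatter.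

Compound 4 `O=C(/C=C/c1cn(S(=O)(=O)c2cccc3ccccc23)c2ccccc12)c1ccncc1` has not yet been measured. It differs from compound 3 in one place: naphthalen-1-yl in place of 2-nitrophenyl on a sulfonyl sulfur. Among the measured compounds shown here, the step from compound 2 to compound 3 is the one measurement bearing on an exchange of this kind, and it stayed inside the scatter, so a small step in this assay is expected again, in no clear direction. On that basis compound 4 is expected to give about 32000 nM, within 12000 nM to 85000 nM. The expected step is a 1.2-fold lower number from compound 3 to compound 4 (0.06 log units; within the scatter).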

Compound 4, half-maximal inhibitory concentration: 58000 nM
Estimate against measurement, compound 4: 1.8-fold (0.26 log units) below, within the range that was stated.
By their numbers in this assay, from the lowest: compounds 3, 2 and 4 (each within the scatter of the next).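

The earlier step exchanged one aromatic group with a single ring for another, whereas this change places naphthalen-1-yl, with 2 six-membered aromatic rings of carbon only, on the sulfonyl sulfur in this assay, and the result is a 1.6-fold higher number from compound 3 to compound 4 (0.20 log units; within the scatter). The comparison with the 4-chlorophenyl compound reads the same way, with a 1.5-fold higher number from compound 2 to compound 4 (0.19 log units; within the scatter). Among these three groups, then, neither adding a second aromatic ring nor replacing the 2-nitrophenyl group with one of carbon only produces a difference that can be told from the scatter, so compounds 2, 3 and 4 cannot be put in order, and all three numbers stay in the same range.

Still open, from the compounds shown here alone, is whether a different kind of group on the sulfonyl sulfur, such as an aromatic ring carrying an amine or a carboxylic acid, or a simple alkyl chain in place of the aromatic group, would move the number beyond the scatter. Nothing in the available evidence explains why these three groups give numbers so close together.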